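This account rests on a few compounds, and the source may have more. Where it says the series, first, only, none or still open, it means among the compounds named here.

Measured compounds:
compound 1 `CCn1cc(-c2ccc(F)cc2)c(=O)c2c(Nc3ccc(Oc4ccnc(NC(=O)C5CC5)c4)c(F)c3)nccc21` — 15.8%
compound 2 `CC(=O)Nc1cc(Oc2ccc(Nc3nccc4[nH]cc(-c5ccc(F)cc5)c(=O)c34)cc2F)ccn1` — 36.8%
compound 3 `CCCC(=O)Nc1cc(Oc2ccc(Nc3nccc4[nH]cc(-c5ccc(F)cc5)c(=O)c34)cc2F)ccn1` — 23.5%

In a functional assay on HT-29 cells (Homo sapiens) for antiproliferative activity, read by MTT assay, with a stated time of 72 h, tested at 10 uM (a lower number here means less inhibition, a higher number more inhibition at the concentration tested (going by the name of the read-out)), compound 1 holds the lowest of the three numbers shown, with compound 3 within the scatter of it and compound 2 beyond it. Going by the values given here, the one step between compounds differing in a single place, a number 13.3 percentage points lower from compound 2 to compound 3 (beyond the scatter), concerns the amide chain and not the position altered here. Compound 4 `Cn1cc(-c2ccc(F)cc2)c(=O)c2c(Nc3ccc(Oc4ccnc(NC(=O)C5CC5)c4)c(F)c3)nccc21` differs from compound 1 by hydrogen in place of methyl on a saturated chain carbon bound to an aromatic nitrogen. Among the compounds with values here, no measured pair isolates this change; compounds 2 and 3 differ from compound 1 in more than one place. A step of a number 2.2 percentage points higher from compound 1 to compound 4 (within the scatter) is therefore expected, none beyond the scatter. Compound 4 is estimated at 18%, between 5% and 35%.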

Compound 4, a percentage reported as inhibition, at one concentration (the size of the read-out at that concentration, not a potency): 24.8%
Compound 4: middle estimate off by 6.8 percentage points, on the low side; low and high end bracket the measured number.
By their numbers in this assay, from the lowest: compounds 1, 3 and 4 (each within the scatter of the next); then compound 2.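

In this assay, going by these compounds alone, ethyl to methyl on the aromatic nitrogen gives a number 9 percentage points higher from compound 1 to compound 4 (within the scatter), the first pair to isolate a change at this position. Shortening this chain by one carbon therefore moves the number by no more than the usual scatter, and the read-out at this position stays low for both compounds. No supporting data bear on this step.

On these data alone, whether a longer chain, a hydroxyethyl group or an aminoethyl group on this nitrogen would give a step beyond the scatter remains open. A single pair also leaves open whether the same change behaves alike with other amide groups.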